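This account rests on a few compounds, and the source may have more. Where it says the series, first, only, none or still open, it means among the compounds named here.

Compound 3 `COc1ccc2c(C(=O)/C(C#N)=C/c3c[nH]c4cc(F)ccc34)c[nH]c2c1` was examined in a functional assay on PC-3 cells (Homo sapiens) for cytotoxicity, read by WST assay, with a stated time of 24 h (a higher number here means a weaker inhibitor, a lower number a stronger inhibitor), and in that test compound 3 gives 36000 nM. Compound 1 `COc1ccc2c(/C=C(\C#N)C(=O)c3c[nH]c4cc(OC)ccc34)c[nH]c2c1` differs from compound 3 by methoxy in place of fluoro on an aromatic carbon. In this assay compound 1 returns only a limit of the assay, > 50000 nM. The step from the measured pair reads an at least 1.3-fold higher number from compound 3 to compound 1 (0.14 log units; that floor lies within the scatter).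

Compound 2 `N#C/C(=C\c1cn(Cc2ccc(Cl)cc2)c2ccccc12)C(=O)c1c[nH]c2cc(F)ccc12` is built on a different core; the difference between the cores of compound 2 and compound 3 is not broken down here. In this assay compound 2 also returns only a limit, > 50000 nM.

Compound 4 `COc1ccc2c(C(=O)/C(C#N)=C/c3cn(Cc4ccc(Cl)cc4)c4ccccc34)c[nH]c2c1` has not yet been measured. It differs from compound 2 by methoxy in place of fluoro on an aromatic carbon, and the place of the change is the same in both pairs, so this is the same change that takes compound 3 to compound 1. The step from compound 2 to compound 4 in this assay is expected to be a step that the limit leaves unreadable from compound 2 to compound 4, an expectation resting on an at least 1.3-fold higher number from compound 3 to compound 1 (0.14 log units; that floor lies within the scatter) and on (the limit of > 50000 nM in this assay, at which 2 of the 3 values shown sit). Compound 4 is accordingly estimated at 80000 nM, with a likely range from 40000 nM to 200000 nM, most probably reported again only as a limit.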

Compound 4, half-maximal inhibitory concentration: > 50000 nM
Compound 4 ended at the assay's limit; the forecaster's own chance of this, stated with the estimate: 80%; the middle value does not contradict the limit.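

Compound 2 and compound 4 both return only a limit in this assay, and the size of the step between them cannot be read. The compounds shown leave open how large the change from 6-fluoro-1H-indol-3-yl to 6-methoxy-1H-indol-3-yl is in this assay on either core, and whether it is the same on both.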